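The source may hold more compounds than are shown below. What is called first, only, known or untested is meant among the compounds shown, and "the series" means these compounds.

Compound 1 `COc1cccc(-c2nn3c(COc4ccnc5cc(OC)ccc45)nnc3s2)c1` and compound 2 `COc1ccc2c(OCc3nnc4sc(-c5cccc(F)c5)nn34)ccnc2c1` share one core and differ in a single group. In a functional assay on EBC-1 cells (Homo sapiens) for antiproliferative activity, with a stated time of 72 h (on this read-out higher numbers stand for weaker inhibition and lower numbers for stronger inhibition), compound 1 gives 472 nM, and compound 2 gives 504 nM, a number that sits alongside that of compound 1, since the step of a 1.1-fold higher number from compound 1 to compound 2 (0.03 log units; within the scatter) stays within the scatter. Compound 3 `COc1ccc2c(OCc3nnc4sc(-c5cc(F)c(F)c(F)c5)nn34)ccnc2c1` carries the next change: 3,4,5-trifluorophenyl in place of 3-fluorophenyl on an aromatic carbon. Among the compounds with values here, the one measured step also altered a group on that same ring and hardly moved the read-out, so in this assay the expected step of a 1.0-fold higher number from compound 2 to compound 3 (0.01 log units; within the scatter) is likewise small, with no clear direction. Compound 3 is therefore estimated at 520 nM, with a likely range from 200 nM to 1400 nM.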

Compound 3, half-maximal inhibitory concentration: 403 nM
Compound 3: the middle estimate sits 1.3-fold (0.11 log units) above what was measured; the range from low to high includes it.
By their numbers in this assay, from the lowest: compounds 3, 1 and 2 (each within the scatter of the next).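

Swapping 3-fluorophenyl for 3,4,5-trifluorophenyl at this position in this assay gives a 1.3-fold lower number from compound 2 to compound 3 (0.10 log units; within the scatter) and swapping 3-methoxyphenyl for it gives a 1.2-fold lower number from compound 1 to compound 3 (0.07 log units; within the scatter) as the second reading. Within the data shown here, the earlier single step compared only two phenyl groups, whereas all three now read alike, even with fluorine on further ring carbons. Nothing measured here offers an explanation for this sameness. Still open, on these data alone, is whether the flat result extends beyond fluoro and methoxy groups. An amine or a carboxylic acid on this phenyl ring, or a longer chain in place of the ring, could read quite differently.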